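The compounds below may be only part of what the source reports. "The series", "measured", "known", "first", "only" and "open" are said of these compounds alone.

Three compounds sharing one core have been examined in an ADME assay on Vero cells (Chlorocebus sabaeus) for cytotoxicity, read by neutral red uptake, tested at 1575 ug/mL; on this read-out lower numbers stand for a stronger effect and higher numbers for a weaker effect at the one concentration tested. Compound 1, `O=C1CSC(c2cccc(F)c2)N1CCN1CCCCC1`, gives 17% in this assay. Compound 2, `O=C1CSC(c2ccccc2Cl)N1CCN1CCCCC1`, gives 16%. Compound 3, `O=C1CSC(c2ccc(O)cc2)N1CCN1CCCCC1`, gives 12%. Compound 3 thus holds the lowest of the three numbers, but the steps of a number 4 percentage points lower from compound 2 to compound 3 (within the scatter) and a number 5 percentage points lower from compound 1 to compound 3 (within the scatter) are both within the scatter, so on these numbers nothing separates compound 3 from the other two beyond the usual scatter.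

Compound 4, `O=C1CSC(c2cccc(Cl)c2)N1CCN1CCCCC1`, has not yet been measured. It differs from compound 3 in one place: 3-chlorophenyl in place of 4-hydroxyphenyl on a saturated ring carbon. Going by the values given here, the steps that bear on this change are the two that exchanged the 4-hydroxyphenyl for a halogen-bearing phenyl, namely a number 5 percentage points lower from compound 1 to compound 3 (within the scatter) and a number 4 percentage points lower from compound 2 to compound 3 (within the scatter), both within the scatter; the exchange of one halogenated phenyl for another, a number 1 percentage points lower from compound 1 to compound 2 (within the scatter), was also within the scatter. No step among these compounds reaches beyond the scatter, so for compound 4 a step in this assay of about a number 4 percentage points higher from compound 3 to compound 4 (within the scatter) is expected, which is no change beyond the scatter. Compound 4 is therefore estimated to give 16% in this assay, with a range from 8% to 26%.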

Compound 4, a percentage reported as activity, at one concentration (the size of the read-out at that concentration, not a potency): 20%
The estimate for compound 4 lay 4 percentage points below the measured number; measured number inside the range.
By their numbers in this assay, from the lowest: compounds 3, 2, 1 and 4 (each within the scatter of the next).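

In this assay, the 4-hydroxyphenyl on the saturated ring carbon, which carries a hydrogen-bond donor and acceptor, can give way to 3-chlorophenyl, which carries neither, with a number 8 percentage points higher from compound 3 to compound 4 (within the scatter) as the result, so losing both leaves no mark beyond the scatter. The new compound also tests the halogen itself: moving the chlorine on the phenyl ring gives a number 4 percentage points higher from compound 2 to compound 4 (within the scatter) and chloro in place of fluoro on an aromatic carbon gives a number 3 percentage points higher from compound 1 to compound 4 (within the scatter) so neither the place of the halogen nor its kind separates these compounds in this assay. No measurement is at hand that could explain the size of these steps.

Going by these compounds, all four compounds keep a singly substituted phenyl on this carbon, so it remains open whether a phenyl bearing a carboxylic acid or an amine, or a longer alkyl chain in place of the phenyl, would step beyond the scatter. On these data alone, it also remains open how the four compare at other concentrations, as each number comes from a single concentration.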